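Replacing the amide side chain of compound 3

This account rests on a few compounds, and the source may have more. Where it says the series, first, only, none or still open, it means among the compounds named here.

Measured so far in a physicochemical assay for lipophilicity, measured as octanol-water partition, at pH 7.4; a lower number here means a more polar compound, a higher number a more lipophilic compound:

- Compound 1 `Cc1ccc2[nH]c(C(=O)N[C@H]3CN(S(=O)(=O)c4cn(C)nc4C)C[C@@H]3C(=O)NCCN(C)C)cc2c1` gives 1.4
- Compound 2 `Cc1ccc2[nH]c(C(=O)N[C@H]3CN(S(=O)(=O)c4ccccc4)C[C@H]3C(=O)NCCN(C)C)cc2c1` gives 2.3
- Compound 3 `Cc1ccc2[nH]c(C(=O)N[C@H]3CN(S(=O)(=O)c4ccccc4)C[C@@H]3C(=O)NC[C@@H]3CCCN3C)cc2c1` gives 2.3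

Compound 3 at 2.3 stands level with compound 2, the two together holding the highest number of the three, while compound 1 lies lower, beyond the usual scatter. Compound 4 `Cc1ccc2[nH]c(C(=O)N[C@H]3CN(S(=O)(=O)c4ccccc4)C[C@@H]3C(=O)N[C@@H]3CCCNC3)cc2c1` has not yet been measured. It carries piperidin-3-yl in place of (1-methylpyrrolidin-2-yl)methyl on an amide-type nitrogen as its only difference. Within the data shown here, no measured pair shows such a change, so the expectation rests on the structural change alone. Expected in this assay is a number 0.50 log units lower from compound 3 to compound 4 (beyond the scatter) as a moderate fall, somewhat beyond the scatter. Compound 4 is estimated at 1.8 with 1.2 as the expected lower end and 2.3 as the upper end.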

Compound 4, distribution coefficient: 1.3
The estimate for compound 4 lay 0.50 log units above the measured number; the range from low to high includes it.
By their numbers in this assay, from the lowest: compounds 4 and 1 (each within the scatter of the next); then compounds 2 and 3 (each within the scatter of the next).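

Among these compounds, the side chain on this amide-type nitrogen is not neutral in this assay: the exchange of (1-methylpyrrolidin-2-yl)methyl for piperidin-3-yl gives a number 1.00 log units lower from compound 3 to compound 4 (beyond the scatter), the first single-place step. The entering group counts 1 hydrogen-bond donor where the leaving group counts 0, and it has a six-membered rather than a five-membered ring, but nothing shown gives a reason for the step. The compounds leave open how much of the step follows the ring and how much the methyl group on the ring nitrogen. A 1-methylpiperidin-3-yl group at this place would separate the two.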